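A Longer Chain Ahead of the Hydroxycarbamoyl Group

This account rests on a few compounds, and the source may have more. Where it says the series, first, only, none or still open, it means among the compounds named here.

For the measured compounds named here, in a functional assay on HepG2 cells (Homo sapiens) for inhibition, read by MTT assay, with a stated time of 48 h (on this read-out higher numbers stand for weaker inhibition and lower numbers for stronger inhibition), two compounds have numbers so far. Compound 1 (`O=C(CCCCCCCOc1cccc(-c2nc3ccc(-c4nc5ccccc5[nH]4)cc3[nH]2)c1)NO`) gives 16000 nM, and compound 2 (`O=C(CCCCCCOc1cccc(-c2nc3ccccc3[nH]2)c1)NO`) gives 3900 nM. Compound 2 therefore holds the lower of the two numbers, and the gap between them lies beyond the usual scatter.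

Compound 3 (`O=C(CCCCCCCOc1cccc(-c2nc3ccccc3[nH]2)c1)NO`) has not yet been measured in this assay. It differs from compound 2 in one place: (hydroxycarbamoyl)methyl in place of hydroxycarbamoyl on a saturated chain carbon, six bonds along the chain from an oxygen on an aromatic ring. In words, (hydroxycarbamoyl)methyl stands in place of hydroxycarbamoyl on a saturated chain carbon, six bonds along the chain from an oxygen on an aromatic ring. The rest of the structure stays as it is.

Going by the values given here, no measured pair shows a change of this kind, so the only anchor is compound 2 at 3900 nM. No shift beyond the usual scatter is expected, and any slight direction is only a guess, leaning toward stronger inhibition. The estimated shift is a 1.3-fold lower number from compound 2 to compound 3 (0.11 log units; within the scatter). For compound 3 the expected value is 3000 nM, with an estimated range from 1000 nM to 9000 nM.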

Compound 3, half-maximal inhibitory concentration: 4800 nM
Compound 3: the middle estimate sits 1.6-fold (0.20 log units) below what was measured, within the range that was stated.
By their numbers in this assay, from the lowest: compounds 2 and 3 (each within the scatter of the next); then compound 1.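

In this assay, (hydroxycarbamoyl)methyl in place of hydroxycarbamoyl, on a saturated chain carbon six bonds along the chain from an oxygen on an aromatic ring, gives a 1.2-fold higher number from compound 2 to compound 3 (0.09 log units; within the scatter) and so leaves the read-out within the scatter over this one change of chain length. Compound 3 also gives compound 1 its first partner that differs in one place, and hydrogen in place of 1H-benzimidazol-2-yl on an aromatic carbon gives a 3.3-fold lower number from compound 1 to compound 3 (0.52 log units; beyond the scatter) in this read-out. The gap beyond the scatter between compounds 1 and 2 thus goes with the 1H-benzimidazol-2-yl group and not with the chain, although nothing at hand gives a reason for either step.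

The compounds shown leave open whether a longer chain, such as one ending in 4-(hydroxycarbamoyl)butyl, would also stay within the scatter, and whether a carboxylic acid in place of the hydroxycarbamoyl group would keep the inhibition. They also leave open how a smaller group, such as an amine, would read on the aromatic carbon that carries 1H-benzimidazol-2-yl in compound 1.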